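Swapping the benzothiazole for a tolyl urea

A few compounds are considered here, and "the series" means these few. Any claim that something is new, unique, unknown or untested is made for them only; others in the source may bear on it.

Measured compounds:
- compound 1, `CC(C)[C@H](NC(=O)c1cc(-c2ccc(Nc3nc4ccc(F)cc4s3)cc2)no1)C(=O)O`: 120000 nM
- compound 2, `CC(C)[C@H](NC(=O)c1cc(-c2ccc(NC(=O)Nc3ccc(Cl)cc3Oc3ccccc3)cc2)no1)C(=O)O`: 86000 nM

Both compounds were tested in an assay on isolated protein for inhibition of chondroitin sulfate N-acetylgalactosaminyltransferase 1 (Homo sapiens), read by scintillation counting, with a stated time of 10 min; on this read-out lower numbers stand for stronger inhibition and higher numbers for weaker inhibition. Compound 1 has the higher of the two numbers, but its gap to compound 2 lies within the usual scatter of the assay, so the two cannot be told apart on this evidence. Both are weak inhibitors.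

Compound 3, `Cc1ccc(NC(=O)Nc2ccc(-c3cc(C(=O)N[C@H](C(=O)O)C(C)C)on3)cc2)cc1`, has not yet been measured. Compared with compound 1 it carries (4-methylphenyl)carbamoyl in place of 6-fluoro-1,3-benzothiazol-2-yl on a nitrogen on an aromatic ring. The new group is a urea that links the shared core to an aromatic ring, a motif that compound 2 also has, and compound 2 gives 86000 nM in this assay, a number within the scatter of compound 1.

Within the data shown here, since no measured pair isolates this exact change, the expectation rests on these two values alone. The step in this assay from compound 1 to compound 3 is expected to be a 1.2-fold lower number from compound 1 to compound 3 (0.08 log units; within the scatter), that is, no change beyond the scatter. Compound 3 is therefore estimated at 100000 nM, in a range from 40000 nM to 250000 nM.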

Compound 3, half-maximal inhibitory concentration in the chondroitin sulfate N-acetylgalactosaminyltransferase 1 assay: 61000 nM
Beside the measured number, compound 3's estimate is 1.6-fold (0.21 log units) above it, and the stated range covers the measured number.
By their numbers in the chondroitin sulfate N-acetylgalactosaminyltransferase 1 assay, from the lowest: compounds 3, 2 and 1 (each within the scatter of the next).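

In the chondroitin sulfate N-acetylgalactosaminyltransferase 1 assay, this position on a nitrogen on an aromatic ring now has a single exchange to read: (4-methylphenyl)carbamoyl in place of 6-fluoro-1,3-benzothiazol-2-yl gives a 2.0-fold lower number from compound 1 to compound 3 (0.29 log units; within the scatter). Inhibition therefore stays weak, and swapping the two-ring group for a urea-linked aromatic ring does not separate the two compounds in this assay. The same exchange does separate them in a physicochemical assay for solubility, with a stated time of 24 h, at pH 7.4 (a higher number here means a more soluble compound, a lower number a less soluble compound), where compound 1 gives 60 ug/mL and compound 3 gives 380 ug/mL, so the change at this position shifts solubility without any readable gain in inhibition: the measured solubility of compound 1, 60 ug/mL, and of compound 3, 380 ug/mL, a 6.3-fold higher number (0.80 log units; beyond the scatter)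

Among these compounds, with only this one exchange, it remains open which part of it carries the difference in solubility, the urea link or the 4-methylphenyl ring that replaces the 6-fluoro-1,3-benzothiazol-2-yl group. Also open, going by these compounds, is whether any group on this nitrogen can move inhibition beyond the scatter, for example a urea ending in a short chain that carries an amine instead of the 4-methylphenyl ring, and how such a group would read in the chondroitin sulfate N-acetylgalactosaminyltransferase 1 assay and the physicochemical assay.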